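A few compounds are considered here, and "the series" means these few. Any claim that something is new, unique, unknown or untested is made for them only; others in the source may bear on it.

Measured compounds:

Compound 1 `CCOC(=O)c1ccc(-c2nn(C)c3ccccc23)cc1`; compound 2 `CCOC(=O)c1ccc(-c2nn(CC)c3ccccc23)cc1`; compound 3 `CNC(=O)c1ccc(-c2nn(Cc3ccccc3)c3ccccc23)cc1`.

In a functional assay on cells (Platelet, Homo sapiens) for inhibition (a lower number here means a stronger inhibitor, a higher number a weaker inhibitor), compound 1 gives only the limit > 10000 nM. Compound 2 also gives only the limit > 10000 nM in this assay. Compound 3 gives only the limit > 10000 nM in this assay. The step that the two limits leave unreadable from compound 1 to compound 2 is therefore unreadable because of the limit of > 10000 nM in this assay, at which 3 of the 3 values shown sit.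

The change from compound 1 to compound 2 is methyl in place of hydrogen on a saturated chain carbon bound to an aromatic nitrogen. Compound 4 `CCNC(=O)c1ccc(-c2nn(Cc3ccccc3)c3ccccc23)cc1` differs from compound 3 by methyl in place of hydrogen on a saturated chain carbon bound to an amide-type nitrogen. It is the same kind of change, though the place differs: in the first pair the saturated chain carbon is bound to an aromatic nitrogen, in the second to an amide-type nitrogen. How the core of compound 1 and the core of compound 3 differ is not broken down here.

For compound 4 the step that the limit leaves unreadable from compound 3 to compound 4 is expected to stay unreadable, resting on compound 3 at > 10000 nM and on (the limit of > 10000 nM in this assay, at which 3 of the 3 values shown sit). Compound 4 is estimated at 15000 nM in this assay.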

Compound 4, half-maximal inhibitory concentration: > 10000 nM
Compound 4 gave a limit, no number; the forecaster's own chance of this, stated with the estimate: 85%; the middle value does not contradict the limit.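

Compound 3 and compound 4 both give only a limit in this assay, so no step between them can be read: the limit of > 10000 nM in this assay, at which 4 of the 4 values shown sit.

The compounds shown leave open which structure in this series, if any, would give a number rather than a limit in this assay.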